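Replacing 4-nitrophenyl in a series of weak MCF7 inhibitors

This account rests on a few compounds, and the source may have more. Where it says the series, first, only, none or still open, it means among the compounds named here.

Values in a functional assay on MCF7 cells (Homo sapiens) for inhibition, read by MTT assay, with a stated time of 72 h; on this read-out higher numbers stand for weaker inhibition and lower numbers for stronger inhibition:
- Compound 1 `COc1ccc(-c2nnc(SCCCN3CCN(c4nc5ccccc5o4)CC3)o2)cc1` gives 52800 nM
- Compound 2 `Oc1ccc(-c2nnc(SCCCN3CCN(c4nc5ccccc5o4)CC3)o2)cc1` gives 260000 nM
- Compound 3 `O=[N+]([O-])c1ccc(-c2nnc(SCCCN3CCN(c4nc5ccccc5s4)CC3)o2)cc1` gives 118000 nM

Compound 3, at 118000 nM, holds the second highest of the three numbers. Compound 4 `O=C(NCc1nnc(SCCCN2CCN(c3nc4ccccc4s3)CC2)o1)c1ccccc1` has not yet been measured. It differs from compound 3 by benzamidomethyl in place of 4-nitrophenyl on an aromatic carbon. Within the data shown here, the only measured step is a 4.9-fold higher number from compound 1 to compound 2 (0.69 log units; beyond the scatter), a modest one, and it reflects a different change, so it indicates only a rough scale. Among the measured compounds shown here, no measured step covers this replacement, so the data give no direction, and no step beyond the scatter is expected in this assay. The expected step is a 1.2-fold lower number from compound 3 to compound 4 (0.07 log units; within the scatter). Compound 4 is estimated at 100000 nM, with an expected range from 35000 nM to 280000 nM.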

Compound 4, half-maximal inhibitory concentration: 39000 nM
Beside the measured number, compound 4's estimate is 2.6-fold (0.41 log units) above it; the range from low to high includes it.
By their numbers in this assay, from the lowest: compounds 4 and 1 (each within the scatter of the next); then compound 3; then compound 2.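

In this assay, among these compounds, benzamidomethyl in place of 4-nitrophenyl gives a 3.0-fold lower number from compound 3 to compound 4 (0.48 log units; beyond the scatter) as the first measured step at this position, so the group held here can shift the number beyond the scatter. The entering group carries a hydrogen-bond donor that 4-nitrophenyl lacks, but this single step cannot separate that difference from the others between the two groups. No available evidence accounts for the step.

On these data alone, it remains open which part of benzamidomethyl matters, and how an aminomethyl group or a carboxylic acid would read at this place.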